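Aryl Variation on the Carbon Double-Bonded to Nitrogen

The source may hold more compounds than are shown below. What is called first, only, known or untested is meant among the compounds shown, and "the series" means these compounds.

Two members of the shared core have been measured so far in a functional assay on the whole organism (strain Wistar) for inhibition, with Rattus norvegicus as the target, read by paw edema, with stated times of 30 min and 3 h, at a dose of 0.05 mmol/kg by the oral route; on this read-out lower numbers stand for less inhibition and higher numbers for more inhibition at the one dose given (going by the name of the read-out). Compound 1 `Cc1cc(O)ccc1C1=NN(c2ccc(S(C)(=O)=O)cc2)C(=O)CC1` gives 33.3%. Compound 2 `CS(=O)(=O)c1ccc(N2N=C(c3ccc(O)c(Cl)c3)CCC2=O)cc1` gives 43.3%. On these two numbers compound 2 stands highest, but its gap to compound 1 is within the scatter, so the pair cannot be ranked. For the measured compounds named here, the single measured step, a number 10 percentage points higher from compound 1 to compound 2 (within the scatter), is therefore read as no change in the inhibition of paw edema.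

Compound 3 `CS(=O)(=O)c1ccc(N2N=C(c3ccc(F)cc3)CCC2=O)cc1` is the next member and has not been measured. It differs from compound 2 by 4-fluorophenyl in place of 3-chloro-4-hydroxyphenyl on a carbon with a double bond to nitrogen. Going by the values given here, the only measured step at this position is a number 10 percentage points higher from compound 1 to compound 2 (within the scatter); it was within the scatter, and no step at any other position is available. Among the compounds with values here, the incoming group lacks the hydroxyl and the chlorine of the outgoing one, which is a larger change than the one measured, but nothing in the two numbers so far points in either direction. No step beyond the scatter is expected, as a number 5.3 percentage points lower from compound 2 to compound 3 (within the scatter). For compound 3 the estimate in this assay is 38%, with a range from 22% to 54%.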

Compound 3, a percentage reported as inhibition, in the whole organism at one dose (the size of the read-out at that dose, not a potency): 60%
Estimate against measurement, compound 3: 22 percentage points below; the measured number lies above the stated range.
By their numbers in this assay, from the lowest: compounds 1 and 2 (each within the scatter of the next); then compound 3.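

In this assay the group on a carbon with a double bond to nitrogen now gives steps beyond the scatter: 4-fluorophenyl in place of 3-chloro-4-hydroxyphenyl is a number 16.7 percentage points higher from compound 2 to compound 3 (beyond the scatter) and 4-fluorophenyl in place of 4-hydroxy-2-methylphenyl is a number 26.7 percentage points higher from compound 1 to compound 3 (beyond the scatter) in the same read-out. The position therefore responds to the choice of aryl group, which the pair of compound 1 and compound 2 could not show, and both steps run the same way, towards the group with 0 hydrogen-bond donors and 0 hydrogen-bond acceptors and away from groups bearing a hydroxyl. The steps rest on whole-group exchanges, and nothing measured here explains them.

The compounds shown do not separate the loss of the hydroxyl from the loss of the chlorine or the methyl, nor the part played by the fluorine itself, so plain phenyl, 4-hydroxyphenyl and 4-chlorophenyl would each bear on that question. Also open, from the compounds shown here alone, is how an amine, a carboxylic acid or a longer chain on this aryl ring would read, and whether changes elsewhere on the shared core would add to the step seen here.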